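The source may report more compounds than this note shows. Statements on the series, on what has been measured and on what is new or still open speak of the compounds shown alone.

- Compound 1 `C#C[C@]1(CO)O[C@@H](n2cc(C)c(=O)[nH]c2=O)C[C@@H]1O`: > 380000 nM, a limit and not a number
- Compound 2 `C#C[C@]1(CO)O[C@@H](n2cc(CC)c(=O)[nH]c2=O)C[C@@H]1O`: > 360000 nM, a limit and not a number
- Compound 3 `C#C[C@]1(CO)O[C@@H](n2cc(F)c(=O)[nH]c2=O)C[C@@H]1O`: 3400 nM

Going by the values given here, in a functional assay on MT4 cells (Homo sapiens), read by MTT assay (on this read-out lower numbers stand for higher toxicity in this test and higher numbers for lower toxicity in this test), compound 3 gives 3400 nM, the only true number of the three and the lowest. Compound 4 `C#C[C@]1(CO)O[C@@H](n2cc(Cl)c(=O)[nH]c2=O)C[C@@H]1O` differs from it by a single change: chloro in place of fluoro on an aromatic carbon. Among the compounds with values here, two measured steps bear on this, both large and both bringing in fluoro at that place: an at least 110-fold lower number from compound 1 to compound 3 (2.04 log units; beyond the scatter), and an at least 100-fold lower number from compound 2 to compound 3 (2.02 log units; beyond the scatter). Neither involves chloro, so they give the direction better than the size. Moving away from fluoro is therefore expected to raise the number, and the expected step is a 15-fold higher number from compound 3 to compound 4 (1.17 log units; beyond the scatter). For compound 4 the estimate is 50000 nM, with an expected range from 6000 nM to 350000 nM.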

Compound 4, half-maximal cytotoxic concentration: 81700 nM
Compound 4: the middle estimate sits 1.6-fold (0.21 log units) below what was measured, and the stated range covers the measured number.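

Having a halogen at this place is not enough to give the low number of compound 3, as the two halogens differ widely in this assay: a 24-fold higher number from compound 3 to compound 4 (1.38 log units; beyond the scatter). Chloro nevertheless reads as more toxic in this test than either alkyl group, with an at least 4.4-fold lower number from compound 2 to compound 4 (0.64 log units; beyond the scatter) and an at least 4.6-fold lower number from compound 1 to compound 4 (0.66 log units; beyond the scatter). Both of those sizes are minimums, since each rests on a limit and not a number.

The compounds shown leave open how bromo or iodo would read at this place. Also open, on these data alone, is how an amine or a longer chain would compare.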